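Thiophene in Place of Phenyl on a Shared Amide Core

The source may hold more compounds than are shown below. What is called first, only, known or untested is meant among the compounds shown, and "the series" means these compounds.

Compound 1 `O=C(Nc1ccc(-c2cscn2)cc1)C1CCCN(Cc2ccc(F)cc2)C1` and compound 2 `O=C(Nc1ccc(-c2ccccc2)cc1)C1CCCN(Cc2ccc(F)c(F)c2)C1` are built on the same amide core and differ in the aromatic group on that core and in the fluorine count on the benzyl group. In a functional assay on A-375 cells (Homo sapiens) for activation, with a stated time of 3 days (on this read-out lower numbers stand for an effect already at smaller amounts and higher numbers for an effect only at larger amounts of compound), compound 1 gives 5000 nM. In this assay compound 2 gives 5000 nM, level with compound 1 at the digits shown, so the two values lie within the usual scatter of this read-out.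

Compound 3 `O=C(Nc1ccc(-c2cccs2)cc1)C1CCCN(Cc2ccc(F)c(F)c2)C1` carries thiophen-2-yl in place of phenyl on an aromatic carbon. Within the data shown here, no step between measured compounds sizes this change. The aromatic group of compound 2 also differs from that of compound 1. In this assay compound 1 sits at 5000 nM, which gives no hint that swapping this group moves the read-out. The step from compound 2 to compound 3 is therefore expected to be none beyond the scatter, no change at the digits printed from compound 2 to compound 3 (within the scatter). Compound 3 is estimated at 5000 nM, with a range from 2000 nM to 12000 nM.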

Compound 3, half-maximal effective concentration: 530 nM
The estimate for compound 3 lay 9.4-fold (0.97 log units) above the measured number, and the stated range ends above it.
By their numbers in this assay, from the lowest: compound 3; then compounds 1 and 2 (each within the scatter of the next).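

In this assay the group on this aromatic carbon, para to a large group, proves to matter: thiophen-2-yl in place of phenyl gives a 9.4-fold lower number from compound 2 to compound 3 (0.97 log units; beyond the scatter) with the rest of the molecule unchanged. The level values of compound 1 and compound 2 could not show this, since those two compounds differ in two places at once and neither change can be read alone from them. This single step sizes the swap only alongside the benzyl group of compound 2. Nothing at hand explains why this swap lowers the number.

The compounds shown leave open how thiophen-3-yl or furan-2-yl would read on the same aromatic carbon. They also leave open whether thiophen-2-yl gives a step of similar size alongside the benzyl group of compound 1.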